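A few compounds are considered here, and "the series" means these few. Any claim that something is new, unique, unknown or untested is made for them only; others in the source may bear on it.

Within the data shown here, compound 1 `CCC(=O)OC[C@H]1O[C@@H](n2cnc3c(OC)ncnc32)[C@@H](OC(=O)CC)[C@@H]1OC(=O)CC` gives 3550000 nM in a physicochemical assay for solubility, in phosphate buffer (on this read-out higher numbers stand for higher solubility and lower numbers for lower solubility), the lowest of the two numbers measured so far. Compound 2 `CCC(=O)O[C@H]1[C@H](OC(=O)CC)[C@@H](CO)O[C@H]1n1cnc2c(OC)ncnc21` gives 23500000 nM in this assay, and the step of a 6.6-fold higher number from compound 1 to compound 2 (0.82 log units; beyond the scatter) came from hydrogen in place of propanoyl on an oxygen on a saturated carbon. Compound 3 `CCC(=O)OC[C@H]1O[C@@H](n2cnc3c(OC)ncnc32)[C@@H](O)[C@@H]1OC(=O)CC` differs from compound 1 by hydrogen in place of propanoyl on an oxygen on a saturated carbon, the same kind of change at a different oxygen, so a rise in this assay of roughly that size is expected. For compound 3 the estimated result is 15000000 nM, with a range from 6000000 nM to 40000000 nM. This corresponds to an expected step of a 4.2-fold higher number from compound 1 to compound 3 (0.63 log units; beyond the scatter).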

Compound 3, solubility: 2390000 nM
Compound 3: the middle estimate sits 6.3-fold (0.80 log units) above what was measured; measured number below the stated range.
By their numbers in this assay, from the lowest: compounds 3 and 1 (each within the scatter of the next); then compound 2.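

In this assay, the change from propanoyloxy to hydroxy on this oxygen gives a 1.5-fold lower number from compound 1 to compound 3 (0.17 log units; within the scatter), whereas the same exchange at a different oxygen gave a 6.6-fold higher number from compound 1 to compound 2 (0.82 log units; beyond the scatter). Removing a propanoyl from compound 1 therefore does not have the same outcome at each oxygen tested. Nothing available explains this difference between the two oxygens. Still open, from the compounds shown here alone, is how an acetyl, a longer acyl chain or an amine would read on this same oxygen. Going by these compounds, the outcome at the remaining propanoyl of compound 1 is also open.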